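This account rests on a few compounds, and the source may have more. Where it says the series, first, only, none or still open, it means among the compounds named here.

Of the compounds shown here, three have been tested so far in a functional assay on the whole organism (strain Sprague-Dawley) for inhibition, with Rattus norvegicus as the target; a higher number here means that more compound is needed for the effect, a lower number that less compound is needed. Compound 1 `CCc1cccc2cc(C(=O)O)cnc12` gives 75 mg/kg, compound 2 `COc1cccc2cc(C(=O)O)cnc12` gives 150 mg/kg, and compound 3 `FC(F)(F)c1cccc2cc(-c3nn[nH]n3)cnc12` gives 25 mg/kg. Compound 3 therefore has the lowest number of the three, and its gap to the nearest, compound 1, lies beyond the scatter. Among the compounds with values here, the only change measured between two compounds so far is a 2.0-fold higher number from compound 1 to compound 2 (0.30 log units; within the scatter), which does not involve the group that is now to be swapped.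

Compound 4 `O=C(O)c1cnc2c(C(F)(F)F)cccc2c1` differs from compound 3 in one place: carboxy in place of 2H-tetrazol-5-yl on an aromatic carbon. Within the data shown here, no measured pair shows this exact swap, so nothing directly tells its size. What the numbers do show is that both compounds carrying the carboxy group, compound 1 and compound 2, gave higher numbers than compound 3, while compound 3 alone carries both the tetrazole and the trifluoromethyl group, so the two differences cannot be separated. On that basis the step of a 3.0-fold higher number from compound 3 to compound 4 (0.48 log units; beyond the scatter) is expected to raise the number, though with wide uncertainty. Compound 4 is therefore estimated at 75 mg/kg, within a range from 25 mg/kg to 200 mg/kg.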

Compound 4, minimum effective dose: 75 mg/kg
Compound 4: the middle estimate sits on the measured number at the digits printed; the measured number falls inside the stated range.
By their numbers in this assay, from the lowest: compound 3; then compounds 1, 4 and 2 (each within the scatter of the next).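

With trifluoromethyl held fixed, carboxy in place of 2H-tetrazol-5-yl gives a 3.0-fold higher number from compound 3 to compound 4 (0.48 log units; beyond the scatter) in this assay, so this swap on the aromatic carbon two atoms from the ring nitrogen moves the number beyond the scatter by itself, and the two differences carried by compound 3 can now be told apart. With carboxy held fixed, trifluoromethyl in place of methoxy gives a 2.0-fold lower number from compound 2 to compound 4 (0.30 log units; within the scatter), and trifluoromethyl in place of ethyl gives no change at the digits printed from compound 1 to compound 4 (within the scatter), so neither of these steps leaves the scatter. No independent measurement is available to explain these results.

Going by these compounds, whether the same swap gives a similar step with ethyl or methoxy on the core remains open. Also open, on these data alone, is how an amide or a nitrile would compare with carboxy and 2H-tetrazol-5-yl at this position.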